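Hydroxyethyl in Place of Phenylethyl on an Amine Nitrogen

A few compounds are considered here, and "the series" means these few. Any claim that something is new, unique, unknown or untested is made for them only; others in the source may bear on it.

Measured compounds:
compound 1, `O=C(NCc1ccc(F)cc1)c1nc(NCCO)c2cccnc2c1O`: "not determined" (no result reported)
compound 2, `C[C@@H](Nc1c(C(=O)NCc2ccc(F)cc2)nc(Br)c2cccnc12)c1ccccc1`: > 20000 nM

Two compounds are shown, but only one carries a number-like entry. In a functional assay on HCT-116 cells (Homo sapiens) for cytotoxicity, read by MTT assay, with a stated time of 72 h (on this read-out higher numbers stand for weaker inhibition and lower numbers for stronger inhibition), compound 1 has no result reported, "not determined" (no result reported). In this assay compound 2 reaches only the limit of the assay, > 20000 nM, which is a limit and not a measured number. Among the two entries, (the limit of > 20000 nM in this assay, at which 1 of the 2 values shown sits). Among the compounds with values here, no pair of measured compounds differing in a single place exists here, so no measured step can anchor an expectation.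

Compound 3, `O=C(NCc1ccc(F)cc1)c1nc(Br)c2cccnc2c1NCCO`, differs from compound 2 in one place: 2-hydroxyethyl in place of 1-phenylethyl on a nitrogen on an aromatic ring. Since compound 2 stands at a limit, the step to compound 3 can only be judged by expectation, and the change from 1-phenylethyl to 2-hydroxyethyl gives no measured basis for a direction. The estimate for compound 3 therefore means a step that the limit leaves unreadable from compound 2 to compound 3, not beyond the scatter. Compound 3 is expected to give about 25000 nM, within a range from 8000 nM to 80000 nM.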

Compound 3, half-maximal inhibitory concentration: > 20000 nM
Compound 3 gave a limit, no number; the forecaster's own chance of this, stated with the estimate: 70%; the middle value does not contradict the limit.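

Within the data shown here, compound 2 and compound 3 both stand at a limit in this assay, not at a number, and no step between them can be read. The compounds shown leave open how strongly either acts on these cells, and whether 2-hydroxyethyl in place of 1-phenylethyl on the nitrogen changes the read-out at all.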